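A few compounds are considered here, and "the series" means these few. Any claim that something is new, unique, unknown or untested is made for them only; others in the source may bear on it.

In a physicochemical assay for lipophilicity, read by HPLC, measured as chromatographic lipophilicity, at pH 7.4 (on this read-out lower numbers stand for lower lipophilicity and higher numbers for higher lipophilicity), compound 1 (`O=C(c1ccccc1)N1CCC(C(=O)N2N=CCC2c2ccccc2)CC1`) gives 4.4, while compound 2 (`CCC(=O)N1CCC(C(=O)N2N=CCC2c2ccccc2)CC1`) gives 3.2, the lower of the two numbers. Compound 3 (`O=C(C1CCN(c2ccccc2)CC1)N1N=CCC1c1ccccc1`) has not yet been measured. It differs from compound 2 by phenyl in place of propanoyl on an amine nitrogen in a ring. Among the measured compounds shown here, only one measured step bears on this change: a number 1.20 log units lower from compound 1 to compound 2 (beyond the scatter), a large step beyond the scatter, with ethyl in place of phenyl on a carbonyl carbon. The two changes are not the same, but here phenyl enters rather than leaves, so a large rise of similar size is expected in this assay. The expected change is a number 1.30 log units higher from compound 2 to compound 3 (beyond the scatter). For compound 3 the estimated value is 4.5, with an expected range from 4 to 5.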

Compound 3, distribution coefficient: 6.3
Compound 3: the middle estimate sits 1.80 log units below what was measured; the whole stated range lies below it.
By their numbers in this assay, from the lowest: compound 2; then compound 1; then compound 3.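

Among the compounds shown here, at the amine nitrogen in a ring, the earlier compounds carried only a carbonyl-linked group, and compound 3 shows what a phenyl on that nitrogen itself does in this assay: phenyl in place of propanoyl gives a number 3.10 log units higher from compound 2 to compound 3 (beyond the scatter) and is a large step. Phenyl in place of benzoyl still gives a number 1.90 log units higher from compound 1 to compound 3 (beyond the scatter) as a large step, so an aromatic ring alone does not set the number, since compound 1 has one too and compound 3 still reads highest of the three. Nothing at hand explains the size of these steps.

The compounds shown leave open whether the rise follows the aromatic ring on that nitrogen or the absence of the carbonyl. A cyclohexyl or benzyl group on the same nitrogen would separate these two readings.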